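Notes on compounds 1 to 4 and the repeated fluoro step

A few compounds are considered here, and "the series" means these few. Any claim that something is new, unique, unknown or untested is made for them only; others in the source may bear on it.

Measured compounds:
compound 1, `C/N=C(/S)C1=CC(C)(C)Oc2ccc([N+](=O)[O-])cc21`, in a functional assay (aorta) with Rattus norvegicus as the target (a lower number here means that less compound is needed, a higher number that more compound is needed for the effect), compound 1 gives 1.35 nM
compound 2, `C/N=C(/S)C1=CC(C)(CF)Oc2ccc([N+](=O)[O-])cc21`, compound 2 gives 1.62 nM
compound 3, `CC1(CF)C=C(C(=O)NCCC#N)c2cc([N+](=O)[O-])ccc2O1`, compound 3 gives 3.98 nM

From compound 1 to compound 2 the change is fluoro in place of hydrogen on a saturated chain carbon bound to a saturated ring carbon, and the step it made is a 1.2-fold higher number from compound 1 to compound 2 (0.08 log units; within the scatter). From compound 2 to compound 3 the step is a 2.5-fold higher number from compound 2 to compound 3 (0.39 log units; beyond the scatter). Between compound 1 and compound 3 the difference between the two cores is not broken down here; their values show compound 3 sitting highest of the three, beyond the scatter to both.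

Compound 4, `N#CCCNC(=O)C1=CC(CF)(CF)Oc2ccc([N+](=O)[O-])cc21`, is not yet measured. It differs from compound 3 by fluoro in place of hydrogen on a saturated chain carbon bound to a saturated ring carbon, the same change as that from compound 1 to compound 2, and at the same kind of place. Compound 4 is therefore expected to move by about a 1.2-fold higher number from compound 3 to compound 4 (0.07 log units; within the scatter), a step that rests on compound 1 because a 1.2-fold higher number from compound 1 to compound 2 (0.08 log units; within the scatter). Compound 4 is expected at 4.7 nM, with a range of 2.4 nM to 9.5 nM.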

Compound 4, half-maximal effective concentration: 2.24 nM
Compound 4: the middle estimate sits 2.1-fold (0.32 log units) above what was measured; the whole stated range lies above it.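

The new step in this assay is a 1.8-fold lower number from compound 3 to compound 4 (0.25 log units; within the scatter), so methyl to fluoromethyl stays within the scatter here, as it did in the earlier pair. Set side by side, the two occurrences of the change do not differ beyond what repeated measurements allow: the same change on two cores in this assay, a 1.2-fold higher number (0.08 log units; within the scatter) from compound 1 to compound 2 and a 1.8-fold lower number (0.25 log units; within the scatter) from compound 3 to compound 4, 2.1-fold (0.33 log units) apart, within the scatter of two such steps. On these two cores, then, the change carries over with neither step beyond the scatter, but two pairs do not show that it would behave alike on a further core, and they give no reason for the opposite directions of the two printed steps, which may be no more than scatter.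

The compounds shown leave open how difluoromethyl, trifluoromethyl or a longer chain would read on a saturated chain carbon bound to a saturated ring carbon in this assay. They also leave open how an amine or a carboxylic acid in place of the nitrile would read in this assay.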